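Swapping the thioether arm of compound 2 for a pyridylmethyl group

A few compounds are considered here, and "the series" means these few. Any claim that something is new, unique, unknown or untested is made for them only; others in the source may bear on it.

In an assay on membranes from lung for binding affinity to cysteinyl leukotriene receptor 1 (Cavia porcellus) (a lower number here means a stronger inhibitor, a higher number a weaker inhibitor), compound 2 `CC(C)(CC[C@H](SCc1ccccc1C(C)(C)O)c1cccc(CCc2ccc3ccc(Cl)cc3n2)c1)CC(=O)O` gives 0.6 nM, the lowest of the three numbers recorded. Compound 1 `CC(C)(O)CCCSC(CCC(C)(C)CC(=O)O)c1cccc(/C=C/c2ccc3ccc(Cl)cc3n2)c1` gives 1.3 nM in this assay, and compound 3 `CC(C)(CC[C@@H](SCc1ccccc1C(C)(C)O)c1cccc(CCc2ccc3ccc(Cl)cc3n2)c1)CC(=O)O` gives 1.9 nM. Going by the values given here, the only measured step that changes a single place is a 3.2-fold higher number from compound 2 to compound 3 (0.50 log units; beyond the scatter), which rests on (the fact that compounds 2 and 3 differ only in the configuration as drawn). Compound 4 `CC(C)(CC[C@H](SCCc1ccccn1)c1cccc(CCc2ccc3ccc(Cl)cc3n2)c1)CC(=O)O` differs from compound 2 by (pyridin-2-yl)methyl in place of 2-(1-hydroxy-1-methylethyl)phenyl on a saturated chain carbon bound to a sulfur. Among the compounds with values here, no measured step touches this position, so the stereo step offers no direct guide to it; the expectation is therefore a modest weakening with wide uncertainty, namely a 6.7-fold higher number from compound 2 to compound 4 (0.82 log units; beyond the scatter). In this assay compound 4 is estimated to give 4 nM, expected to lie between 1.2 nM and 15 nM.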

Compound 4, half-maximal inhibitory concentration: 2.2 nM
Estimate against measurement, compound 4: 1.8-fold (0.26 log units) above; low and high end bracket the measured number.
By their numbers in this assay, from the lowest: compound 2; then compounds 1, 3 and 4 (each within the scatter of the next).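

Going by these compounds alone, replacing 2-(1-hydroxy-1-methylethyl)benzyl with 2-(pyridin-2-yl)ethyl on the sulfur gives a 3.7-fold higher number from compound 2 to compound 4 (0.56 log units; beyond the scatter) in this assay, the first reading of a change at this position. The arm can lose its hydrogen-bond donor and its tertiary alcohol, and compound 4 still gives 2.2 nM. Nothing shown bears on why this exchange shifts the number.

The compounds shown do not separate the effects of the hydroxyl, the ring nitrogen and the chain. A plain benzyl arm, or an arm ending in an amine or a carboxylic acid, would address this.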